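This account rests on a few compounds, and the source may have more. Where it says the series, first, only, none or still open, it means among the compounds named here.

Working notes on the series, read in an ADME assay on microsomes from liver (Mus musculus) for metabolic stability, read by LC-MS, using NADPH, with a stated time of 10 min, tested at 0.5 uM; a lower number here means that less of the compound is left, a higher number that more of the compound is left. For the measured compounds named here, compound 1 `COC(=O)Nc1cc(-c2cnc(OC[C@@](C)(N)CC(C)C)c(Cl)c2)ccn1` gives 65%, and compound 2 `COC(=O)Nc1cc(-c2cnc(OC[C@@](C)(N)CC(C)C)c(C#N)c2)ccn1` gives 86%, the higher of the two numbers so far. Going by the values given here, the only measured step is a number 21 percentage points higher from compound 1 to compound 2 (beyond the scatter), with cyano in place of chloro on an aromatic carbon.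

Next is compound 3 `COC(=O)Nc1cc(-c2cnc(OC[C@@](C)(N)CC(C)C)c(OC)c2)ccn1`, not yet measured, which carries methoxy in place of cyano on an aromatic carbon. The methoxy stands ortho to the (2-amino-2,4-dimethylpentyl)oxy group. Among the compounds with values here, no measured compound carries methoxy, so the evidence is indirect and rests on one step. That step, a number 21 percentage points higher from compound 1 to compound 2 (beyond the scatter), shows that a swap at this place can move the read-out beyond the scatter. Within the data shown here, compound 2 is also the only measured compound with cyano, and compound 1, without it, gives 65%. A fall of similar size is therefore expected on leaving cyano, though with wide uncertainty. The estimated change is a number 20 percentage points lower from compound 2 to compound 3 (beyond the scatter). For compound 3 the expected value is 66%, with an estimated range from 45% to 84%.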

Compound 3, percent of the compound remaining: 59%
The estimate for compound 3 lay 7 percentage points above the measured number; the measured number falls inside the stated range.
By their numbers in this assay, from the lowest: compounds 3 and 1 (each within the scatter of the next); then compound 2.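

In this assay, the place on the aromatic carbon ortho to the (2-amino-2,4-dimethylpentyl)oxy group now carries three measured groups, and the swap from cyano to methoxy gives a number 27 percentage points lower from compound 2 to compound 3 (beyond the scatter) while both groups count the same number of heavy atoms and hydrogen-bond acceptors, so those counts alone do not follow the read-out at this place. Methoxy and chloro are not separated here, with a number 6 percentage points lower from compound 1 to compound 3 (within the scatter) in the same assay, which leaves cyano as the only one of the three groups standing apart from the other two, on the strength of a single compound carrying it. No measurement here bears on why the number moves with these changes.

Whether cyano stays alone at this place is open, since the compounds shown give no reading for a fluoro, a methyl, an amine or a primary carboxamide there. Also open, going by these compounds, is whether the gap between cyano and the other two groups holds with a shorter chain or a cyclic amine in place of the (2-amino-2,4-dimethylpentyl)oxy group.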